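The source may hold more compounds than are shown below. What is called first, only, known or untested is meant among the compounds shown, and "the series" means these compounds.

Measured compounds in a functional assay on A549 cells (Homo sapiens) for cytotoxicity, with a stated time of 48 h; on this read-out lower numbers stand for stronger inhibition and higher numbers for weaker inhibition:
- compound 1, `C[S+]([O-])/C=C/c1cc(=O)c2cc(Cl)ccc2o1`, gives 1700 nM
- compound 2, `CCCC(=O)Oc1ccc2oc(/C=C/[S+](C)[O-])cc(=O)c2c1`, gives 2200 nM

Within the data shown here, compound 2 has the higher of these two numbers in this assay; its only neighbour is compound 1, and the step of a 1.3-fold higher number from compound 1 to compound 2 (0.11 log units; within the scatter) lies within the scatter, so no order between the two can be read from them.

Compound 3, `CC(=O)Oc1ccc2oc(/C=C/[S+](C)[O-])cc(=O)c2c1`, differs from compound 2 by hydrogen in place of ethyl on a saturated chain carbon bound to a carbonyl carbon. Among the measured compounds shown here, no measured step alters the chain of the ester; the single measured step, a 1.3-fold higher number from compound 1 to compound 2 (0.11 log units; within the scatter), swaps chloro for (propylcarbonyl)oxy on an aromatic carbon and leaves the number within the scatter. That step bears on compound 3 only indirectly: it shows that a large change of the group at that place hardly moves the read-out of this assay, and shortening the ester chain is a smaller change than that. The step from compound 2 to compound 3 is therefore expected to be small, a 1.1-fold lower number from compound 2 to compound 3 (0.04 log units; within the scatter), with no direction beyond the scatter. Compound 3 is estimated at 2000 nM, with a range from 900 nM to 4500 nM.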

Compound 3, half-maximal inhibitory concentration: 4100 nM
Compound 3: middle estimate off by 2.1-fold (0.31 log units), on the low side; the measured number falls inside the stated range.
By their numbers in this assay, from the lowest: compounds 1, 2 and 3 (each within the scatter of the next, the first and the last beyond it).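

In this assay, the shortening of the ester chain gives a 1.9-fold higher number from compound 2 to compound 3 (0.27 log units; within the scatter), so this change of propyl to methyl, the first measured on the chain itself, sets no order between the two compounds. Acetoxy in place of chloro on the aromatic carbon gives a 2.4-fold higher number from compound 1 to compound 3 (0.38 log units; beyond the scatter), a modest step and the first in this series beyond the scatter, whereas (propylcarbonyl)oxy in place of chloro gave a 1.3-fold higher number from compound 1 to compound 2 (0.11 log units; within the scatter); the group at that place can therefore shift the read-out measurably, though here only for acetoxy and by a small margin. Nothing measured alongside these numbers speaks to what lies behind them.

On these data alone, with only propyl and methyl on the ester carbonyl, it remains open whether a longer chain such as pentyl, a branched chain such as isopropyl or a phenyl ring there would follow the same direction or whether the chain has no real effect on the number. As far as these compounds go, it also remains open how a free hydroxyl, a methoxy group or an amine on the aromatic carbon would compare with chloro and the two esters, and whether any of these would move the number further than the steps seen so far.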